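This account rests on a few compounds, and the source may have more. Where it says the series, first, only, none or still open, it means among the compounds named here.

Working notes on the series.

The three measured compounds share one core and differ at the groups on the two ring nitrogens and at the benzyl substituent. Compound 1 `CC(C)Cn1c(=O)c2nc(-c3cnn(Cc4cccc(F)c4)c3)[nH]c2n(CC(C)C)c1=O` gives 830 nM in an assay on CHO cells for displacement of a labelled ligand from adenosine receptor A1 (Homo sapiens); on this read-out lower numbers stand for stronger inhibition and higher numbers for weaker inhibition. Compound 2 `CCn1c(=O)c2nc(-c3cnn(Cc4cccc(F)c4)c3)[nH]c2n(CC)c1=O` gives 380 nM in this assay. Compound 3 `CCCn1c(=O)c2nc(-c3cnn(Cc4cc(C(F)(F)F)ccc4Cl)c3)[nH]c2n(CCC)c1=O` gives 1200 nM in this assay, the highest of the three numbers; its gap to compound 1 lies within the scatter, while compound 2 sits at a number beyond the scatter lower.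

Compound 4 `CCCn1c(=O)c2nc(-c3cnn(Cc4cccc(C)c4)c3)[nH]c2n(CCC)c1=O` differs from compound 3 in one place:

3-methylphenyl in place of 2-chloro-5-(trifluoromethyl)phenyl on a saturated chain carbon bound to an aromatic nitrogen

No step between measured compounds is available, so the expectation rests on the spread shown. Within the data shown here, compound 4 is expected to come out somewhat lower than compound 3, a step of a 2.0-fold lower number from compound 3 to compound 4 (0.30 log units; within the scatter) in this assay, a modest move given that none of the measured numbers lies far apart. For compound 4 the estimate in this assay is 600 nM, with a range from 200 nM to 1800 nM.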

Compound 4, inhibition constant: 48 nM
The estimate for compound 4 lay 13-fold (1.10 log units) above the measured number; measured number outside the range, below it.
By their numbers in this assay, from the lowest: compound 4; then compound 2; then compounds 1 and 3 (each within the scatter of the next).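

In this assay, among these compounds, the exchange on a saturated chain carbon bound to an aromatic nitrogen carries a 25-fold lower number from compound 3 to compound 4 (1.40 log units; beyond the scatter), a large step that shows this position strongly affects the read-out, which the earlier compounds, none a single-place step from another, could not show. The change takes 2-chloro-5-(trifluoromethyl)phenyl, with 11 heavy atoms, to 3-methylphenyl, with 7 heavy atoms, while the groups on the two ring nitrogens stay the same. No supporting data bear on why the step is this large.

As far as these compounds go, whether the step follows the loss of the chlorine, the loss of the trifluoromethyl or the arrival of the methyl remains open, as all three change together here. Also open, from the compounds shown here alone, is how an amine or a carboxylic acid in place of the methyl would read in this assay.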